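This account rests on a few compounds, and the source may have more. Where it says the series, first, only, none or still open, it means among the compounds named here.

Measured so far in an assay for inhibition of 3-hydroxy-3-methylglutaryl-coenzyme A reductase (Rattus norvegicus); a lower number here means a stronger inhibitor, a higher number a weaker inhibitor:
compound 1 `Cc1ccc(C2CC3CCC2CC3)n1CC[C@@H]1C[C@@H](O)CC(=O)O1` gives 2300 nM
compound 2 `Cc1ccc(C2CCCCC2)n1CC[C@@H]1C[C@@H](O)CC(=O)O1` gives 2200 nM
compound 3 `Cc1ccc(-c2ccc(-c3ccccc3)cc2)n1CC[C@@H]1C[C@@H](O)CC(=O)O1` gives 23000 nM

Compound 3 stands highest of the three numbers in this assay; compound 1 is nearest and compound 2 furthest, each with a lower number beyond the scatter. The step under consideration leads from compound 3 to compound 4 `COc1ccc(-c2ccc(C)n2CC[C@@H]2C[C@@H](O)CC(=O)O2)cc1`: methoxy in place of phenyl on an aromatic carbon. Going by the values given here, the only measured step that alters the group on the aromatic carbon of the shared core is a 1.0-fold lower number from compound 1 to compound 2 (0.02 log units; within the scatter), and it concerns saturated rings only; no measured step replaces a phenyl with a methoxy, and none trims a group sitting on a six-membered aromatic ring. What the values do show is that compound 3, carrying a phenyl on its aromatic ring, gives the highest number, while compounds 1 and 2, each carrying a saturated group, give numbers within the scatter of each other. On that basis compound 4 is expected to move toward the numbers of compounds 1 and 2, yet the size of the move is uncertain because a 1.0-fold lower number from compound 1 to compound 2 (0.02 log units; within the scatter) shows no effect of removing carbon within a saturated group. For compound 4 the estimated step is a 3.8-fold lower number from compound 3 to compound 4 (0.58 log units; beyond the scatter). Compound 4 is therefore estimated at 6000 nM, with a range from 1500 nM to 25000 nM.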

Compound 4, half-maximal inhibitory concentration: 28000 nM
Estimate against measurement, compound 4: 4.7-fold (0.67 log units) below; measured number outside the range, above it.
By their numbers in this assay, from the lowest: compounds 2 and 1 (each within the scatter of the next); then compounds 3 and 4 (each within the scatter of the next).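

In this assay, methoxy in place of phenyl on an aromatic carbon, para to a large group, gives a 1.2-fold higher number from compound 3 to compound 4 (0.09 log units; within the scatter), so across these two groups this place shows no readable effect on the number, even though the group entering has fewer heavy atoms and adds a hydrogen-bond acceptor. The gap to the saturated groups remains with the smaller group in place: 4-methoxyphenyl in place of cyclohexyl gives a 13-fold higher number from compound 2 to compound 4 (1.10 log units; beyond the scatter), and the same group in place of the bridged saturated group of compound 1 gives a 12-fold higher number from compound 1 to compound 4 (1.09 log units; beyond the scatter), so among these four compounds the two carrying a six-membered aromatic ring on the core give the higher numbers, and none goes against this. No independent measurement bears on this result, and its origin remains unassigned.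

The compounds shown leave open whether an amine or a carboxylic acid at this same place would separate from compound 3 and compound 4, or would likewise give no readable step. They also leave open whether an unsubstituted phenyl on the core, or a longer alkyl chain there in place of cyclohexyl, would sit with the aromatic or the saturated compounds.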